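A few compounds are considered here, and "the series" means these few. Any claim that something is new, unique, unknown or untested is made for them only; others in the source may bear on it.

Measured so far in a functional assay on SGC-7901 cells (Homo sapiens) for antiproliferative activity, read by MTT assay, with a stated time of 72 h; a lower number here means a stronger inhibitor, a higher number a weaker inhibitor:
compound 1 `COc1ccc(-c2nnc3sc(-c4ccc(C)cc4)nn23)c(OC)c1OC`: 186 nM
compound 2 `COc1ccc(-c2nn3c(-c4ccc(OC)c(OC)c4OC)nnc3s2)cc1N`: 62 nM
compound 3 `COc1ccc(-c2nn3c(-c4ccc(OC)c(OC)c4)nnc3s2)cc1N`: 83 nM

Compound 3 holds the second highest of the three numbers; its nearest neighbour is compound 2, a gap within the scatter, and its furthest is compound 1, a gap beyond it. The two measured steps are a 3.0-fold lower number from compound 1 to compound 2 (0.48 log units; beyond the scatter) and a 1.3-fold higher number from compound 2 to compound 3 (0.13 log units; within the scatter).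

Compound 4 `COc1ccc(-c2nnc3sc(-c4ccc(OC)c(N)c4)nn23)cc1` differs from compound 3 by hydrogen in place of methoxy on an aromatic carbon. One measured step is the same kind of change, a methoxy group giving way to hydrogen: a 1.3-fold higher number from compound 2 to compound 3 (0.13 log units; within the scatter), within the scatter. The other, a 3.0-fold lower number from compound 1 to compound 2 (0.48 log units; beyond the scatter), concerns a different aryl group and does not speak to this change. Among the measured compounds shown here, the only comparable step therefore argues for no movement beyond the scatter, with at most a slight drift toward a higher number. The expected step is a 1.2-fold higher number from compound 3 to compound 4 (0.08 log units; within the scatter). Compound 4 is estimated at 100 nM in this assay, with a range from 50 nM to 210 nM.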

Compound 4, half-maximal inhibitory concentration: 14200 nM
Beside the measured number, compound 4's estimate is 140-fold (2.15 log units) below it, outside the stated range (above it).
By their numbers in this assay, from the lowest: compounds 2 and 3 (each within the scatter of the next); then compound 1; then compound 4.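

In this assay, among the compounds shown here, the series shows a 170-fold higher number from compound 3 to compound 4 (2.23 log units; beyond the scatter) on loss of the methoxy that sits ortho to a methoxy group and meta to a large group, so this place on the ring is highly sensitive, which the earlier compounds did not reveal. Loss of a methoxy is not a change of uniform size on this ring: a 1.3-fold higher number from compound 2 to compound 3 (0.13 log units; within the scatter) concerns another methoxy on the same ring, so the outcome depends on which methoxy leaves. Nothing available explains why this methoxy counts so heavily.

Going by these compounds, whether a hydroxy, an ethoxy or a fluorine at this place would keep the number near that of compound 3 stays open. Also open, on these data alone, is whether this methoxy counts as heavily when the other aryl group lacks its amine.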